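Amide variations on a butylbenzofuranyl ketone series

The source may report more compounds than this note shows. Statements on the series, on what has been measured and on what is new or still open speak of the compounds shown alone.

Compound 1 `CCCCc1oc2ccccc2c1C(=O)c1ccc(OCC(=O)N2CCOCC2)cc1` carries a (morpholin-4-yl)carbonyl group on the chain bound to the aryl oxygen. In a functional assay on HL-60 cells (Homo sapiens) for antiproliferative activity, read by MTT assay, with a stated time of 24 h (on this read-out lower numbers stand for stronger inhibition and higher numbers for weaker inhibition), compound 1 returns only a limit, > 50000 nM. Compound 2 `CCCCc1oc2ccccc2c1C(=O)c1ccc(OCC(=O)NCc2ccccc2)cc1` differs by benzylamino in place of morpholin-4-yl on a carbonyl carbon. Compound 2 likewise returns only a limit in this assay, > 50000 nM. The step that the two limits leave unreadable from compound 1 to compound 2 stays unreadable because of the limit of > 50000 nM in this assay, at which 2 of the 3 values shown sit.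

Compound 3 `CCCCc1oc2ccccc2c1C(=O)c1ccc(OCCCC(=O)N2CCOCC2)cc1` has a longer chain; its core differs from that of compound 1 by 2-((morpholin-4-yl)carbonyl)ethyl in place of (morpholin-4-yl)carbonyl on a saturated chain carbon bound to an oxygen on an aromatic ring. In this assay, going by the values given here, compound 3 gives 34100 nM, the only numeric value in the set. The step of an at least 1.4-fold lower number from compound 1 to compound 3 (0.16 log units; that floor lies within the scatter) and the step of an at least 1.4-fold lower number from compound 2 to compound 3 (0.16 log units; that floor lies within the scatter) are each floors only, both inside the scatter.

Compound 4 `CCCCc1oc2ccccc2c1C(=O)c1ccc(OCCCC(=O)NCc2ccccc2)cc1` is not yet measured. It differs from compound 3 by benzylamino in place of morpholin-4-yl on a carbonyl carbon, the same change as between compound 1 and compound 2, at the same place. That earlier step cannot be sized, so no direction is known for the exchange on the longer core. What is known is that compound 3 sits near the limit in this assay, so a modest shift in either direction may return no number at all.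

Given the value of compound 3, 34100 nM, compound 4 is expected at about 40000 nM in this assay, within a range of 15000 nM to 120000 nM. The expected step of a 1.2-fold higher number from compound 3 to compound 4 (0.07 log units; within the scatter) is accordingly small and uncertain in sign.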

Compound 4, half-maximal inhibitory concentration: 28900 nM
Compound 4: the middle estimate sits 1.4-fold (0.14 log units) above what was measured; low and high end bracket the measured number.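

Working notes on carrying the change across cores: in this assay, benzylamino in place of morpholin-4-yl on a carbonyl carbon gives a 1.2-fold lower number from compound 3 to compound 4 (0.07 log units; within the scatter), so on the longer core compound 3 and compound 4 cannot be told apart and the exchange shows no readable effect. The same change on the core of compound 1 cannot be sized, and the steps from the shorter core to the longer one give no usable size either, because those steps rest on values that are limits and not numbers: the limit of > 50000 nM in this assay, at which 2 of the 4 values shown sit. The series therefore offers a single readable pair, which shows that this exchange is tolerated without a measurable shift on the longer core, but does not show whether the change behaves the same way on both cores, so no transfer from one core to the other can be claimed.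

Still open, from the compounds shown here alone, is whether any other group on the carbonyl carbon, such as piperidin-1-yl, dimethylamino or a free carboxylic acid in place of the amide, would move the number beyond the scatter on either core. Equally open, going by these compounds, is whether a chain longer than that of compound 3 would give a clearly lower number in this assay.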